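Hydrogen in place of hydroxy on an amine nitrogen

The source may hold more compounds than are shown below. What is called first, only, known or untested is meant among the compounds shown, and "the series" means these compounds.

In a functional assay on the whole organism with Mus musculus as the target (on this read-out higher numbers stand for an effect only at larger amounts of compound and lower numbers for an effect already at smaller amounts), compound 1 `CC[C@@H](C(=O)NC)N1CCCC1=O` gives 1800 umol/kg and compound 2 `CC[C@@H](C(=N)NO)N1CCCC1=O` gives 1000 umol/kg on the same read-out. Within the data shown here, the one measured step is a 1.8-fold lower number from compound 1 to compound 2 (0.26 log units; within the scatter) and places compound 2 within the scatter of compound 1, its only neighbour, so the pair gives no ranking. Compound 3 `CC[C@@H](C(=N)N)N1CCCC1=O` differs from compound 2 by one change: hydrogen in place of hydroxy on an amine nitrogen (hydrogen in place of hydroxy on an amine nitrogen, or hydroxyamino to amino). Among the measured compounds shown here, no measured step covers this exchange. For the measured compounds named here, the step into compound 2 involved a different group and is the only guide to how far the numbers move at this place. The step expected in this assay is no change at the digits printed from compound 2 to compound 3 (within the scatter) and no larger than the scatter, with no firm direction. The estimate for compound 3 is 1000 umol/kg with an expected range from 350 umol/kg to 2800 umol/kg around it.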

Compound 3, dose for half-maximal effect: 1000 umol/kg
Compound 3: middle estimate and measured number agree at the digits printed; the measured number falls inside the stated range.
By their numbers in this assay, from the lowest: compounds 2, 3 and 1 (each within the scatter of the next).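

In this assay hydrogen in place of hydroxy on the amine nitrogen gives no change at the digits printed from compound 2 to compound 3 (within the scatter) and so the read-out at this place does not depend on the hydroxy being present. The smaller group of compound 3 also gives a 1.8-fold lower number from compound 1 to compound 3 (0.26 log units; within the scatter) and so this group holds the number within the scatter of the group in compound 1, just as the group in compound 2 does. No measurement at hand bears on why the number holds across this exchange.

Among these compounds, all three compounds lie within the scatter of one another, so no step yet shows how far the number can move at this place. On these data alone, whether a carboxylic acid or a simple amine at this place, or a longer chain in place of the saturated chain, would move it beyond the scatter remains open.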